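This account rests on a few compounds, and the source may have more. Where it says the series, first, only, none or still open, it means among the compounds named here.

Working notes on the series. Three compounds have numbers in an assay on CHO cells for displacement of a labelled ligand from prostaglandin E2 receptor EP3 subtype (Homo sapiens), read by radioligand binding; a higher number here means a weaker inhibitor, a lower number a stronger inhibitor. Compound 1 `CCC(CC)(c1nnc[nH]1)c1ccc(-c2ccc3cc(F)cc(F)c3c2)[nH]c1=O` gives 89 nM there. Compound 2 `CCn1ncc2c(F)cc(-c3ccc(C(CC)(CC)c4nnc(C)[nH]4)c(=O)[nH]3)cc21` gives 34 nM in this assay. Compound 3 `CC(C)C(c1ccc(-c2ccc3cccc(F)c3c2)[nH]c1=O)N1CCCCC1=O` gives 6.4 nM in this assay, the lowest of the three numbers; its gaps to compound 2 and to compound 1 both lie beyond the scatter, so compound 3 is the strongest inhibitor among the measured set.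

Compound 4 `CC(C)C(c1ccc(-c2ccc3cccc(F)c3c2)[nH]c1=O)N1CCNC1=O` is not yet measured. It differs from compound 3 in one place: 2-oxoimidazolidin-1-yl in place of 2-oxopiperidin-1-yl on a saturated chain carbon bound to an aromatic carbon and a saturated chain carbon. Within the data shown here, no measured pair in this set carries the same change, so there is no precedent here for its size or direction; the change is confined to the ring on that saturated chain carbon. Given that the change keeps the rest of compound 3 intact, the step of a 1.9-fold higher number from compound 3 to compound 4 (0.27 log units; within the scatter) is expected to be small, toward a higher number, within or only just beyond the scatter. For compound 4 a value of 12 nM is expected, with a range from 4 nM to 40 nM.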

Compound 4, inhibition constant: 9.1 nM
For compound 4 the middle estimate is 1.3-fold (0.12 log units) above the measured one; the range from low to high includes it.
By their numbers in this assay, from the lowest: compounds 3 and 4 (each within the scatter of the next); then compound 2; then compound 1.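

In this assay, the ring on the saturated chain carbon bound to an aromatic carbon and a saturated chain carbon can be changed with only a small effect on the number: the step is a 1.4-fold higher number from compound 3 to compound 4 (0.15 log units; within the scatter) for 2-oxoimidazolidin-1-yl in place of 2-oxopiperidin-1-yl. Among these compounds, this is the first pair to differ in one place, and it shows that a five-membered non-aromatic ring carrying a hydrogen-bond donor can stand here in place of the six-membered ring without a change beyond the scatter. Nothing available accounts for this result.

Open, going by these compounds, is how a plain piperidin-1-yl amine without the carbonyl, or a carboxylic acid, would read on that carbon. On these data alone, whether the same step would hold on the cores of compound 1 and compound 2 also remains unknown.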